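Removing the Nitro Group: From Compound 1 to Compound 4

A few compounds are considered here, and "the series" means these few. Any claim that something is new, unique, unknown or untested is made for them only; others in the source may bear on it.

Three compounds share one core and differ only in the group carried on a six-membered aromatic ring of carbon only. Compound 1 `CCOC(=O)c1c(N)sc(/N=C/c2ccc([N+](=O)[O-])cc2)c1C(=O)OCC` carries a nitro there, and in a functional assay on T47D cells (Homo sapiens) for inhibition, read by MTT assay, with a stated time of 48 h (on this read-out lower numbers stand for stronger inhibition and higher numbers for weaker inhibition), compound 1 gives 2300 nM, the lowest of the three numbers. Compound 2 `CCOC(=O)c1c(N)sc(/N=C/c2ccc(Cl)cc2)c1C(=O)OCC` carries chloro instead and gives 12100 nM, while compound 3 `CCOC(=O)c1c(N)sc(/N=C/c2ccc(F)cc2)c1C(=O)OCC` carries fluoro and gives 22500 nM. The steps read a 5.3-fold higher number from compound 1 to compound 2 (0.72 log units; beyond the scatter) and a 9.8-fold higher number from compound 1 to compound 3 (0.99 log units; beyond the scatter), whereas a 1.9-fold higher number from compound 2 to compound 3 (0.27 log units; within the scatter). Compound 4 `CCOC(=O)c1c(N)sc(/N=C/c2ccccc2)c1C(=O)OCC` has not yet been measured; it differs from compound 1 by hydrogen in place of nitro on an aromatic carbon. Because the steps of a 5.3-fold higher number from compound 1 to compound 2 (0.72 log units; beyond the scatter) and a 9.8-fold higher number from compound 1 to compound 3 (0.99 log units; beyond the scatter) both weakened inhibition beyond the scatter when nitro was replaced by a halogen, taking the nitro away altogether is also expected to raise the number, by about as much as those two steps, which is what an 8.7-fold higher number from compound 1 to compound 4 (0.94 log units; beyond the scatter) expresses. For compound 4 the expected value is 20000 nM, with a range from 7000 nM to 60000 nM.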

Compound 4, half-maximal inhibitory concentration: 30300 nM
Compound 4: the middle estimate sits 1.5-fold (0.18 log units) below what was measured, within the range that was stated.
By their numbers in this assay, from the lowest: compound 1; then compounds 2, 3 and 4 (each within the scatter of the next, the first and the last beyond it).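

Taking the nitro away without putting anything in its place gives the full size of what it contributes at this position on the aromatic ring (a 13-fold higher number from compound 1 to compound 4 (1.12 log units; beyond the scatter)), and compound 1 remains the strongest of the four. The plain phenyl also serves as a baseline for the halogens: fluoro cannot be told apart from hydrogen (a 1.3-fold higher number from compound 3 to compound 4 (0.13 log units; within the scatter)), whereas chloro keeps a modest edge over it (a 2.5-fold higher number from compound 2 to compound 4 (0.40 log units; beyond the scatter)). No measurement is available that explains why these groups differ.

The compounds shown leave open whether another group at this position, such as a nitrile, an amine or a carboxylic acid, would match the nitro or surpass it. For the compounds shown here, they also carry the nitro at only one place on the ring, so what it would do elsewhere on that ring remains unknown.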